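The source may hold more compounds than are shown below. What is called first, only, known or untested is meant among the compounds shown, and "the series" means these compounds.

Of the compounds shown here, three have been measured in a functional assay on the whole organism for inhibition, with Mus musculus as the target, at a dose of 10 mg/kg; a lower number here means less inhibition, a higher number more inhibition at the dose given (going by the name of the read-out): compound 1 `CCCOCC1=CS(=O)(=O)c2ccccc2C1=O` gives 99.9%; compound 3 `O=C1C(CBr)=CS(=O)(=O)c2ccccc21` gives 92.8%; compound 2 `O=C(OCC1=CS(=O)(=O)c2ccccc2C1=O)c1ccccc1` gives 0%.

Compound 3 stands second highest of the three, with compound 1 nearest and within the scatter and compound 2 far below it, beyond the scatter. Within the data shown here, the only measured step at this carbon, a number 7.1 percentage points lower from compound 1 to compound 3 (within the scatter), is within the scatter. Compound 4 `CCNC(=O)OCC1=CS(=O)(=O)c2ccccc2C1=O` differs from compound 3 by (ethylcarbamoyl)oxy in place of bromo on a saturated chain carbon bound to a double-bonded ring carbon. Among the measured compounds shown here, no measured step covers an (ethylcarbamoyl)oxy group, and compound 2, which also bears a larger group on a saturated chain carbon bound to a double-bonded ring carbon, gives 0%. The expectation for compound 4 is therefore wide: the estimate is 40%, from 0% to 95%.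

The expected step is a number 52.8 percentage points lower from compound 3 to compound 4 (beyond the scatter), a drop beyond the scatter.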

Compound 4, a percentage reported as inhibition, in the whole organism at one dose (the size of the read-out at that dose, not a potency): 99.3%
Compound 4: the middle estimate sits 59.3 percentage points below what was measured; measured number above the stated range.
By their numbers in this assay, from the lowest: compound 2; then compounds 3, 4 and 1 (each within the scatter of the next).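

In this assay the (ethylcarbamoyl)oxy group on this saturated chain carbon stands level with bromo (a number 6.5 percentage points higher from compound 3 to compound 4 (within the scatter)) and with propoxy (a number 0.6 percentage points lower from compound 1 to compound 4 (within the scatter)). A carbonyl-bearing group at this place therefore does not by itself remove the inhibition. The difference lies in ethylamino in place of phenyl on the carbonyl carbon (a number 99.3 percentage points higher from compound 2 to compound 4 (beyond the scatter)), which ties the loss in the benzoate ester to that phenyl.

From the compounds shown here alone, whether a methyl or a phenylamino group on that carbonyl carbon would keep the inhibition stays open. Nothing available explains why the phenyl and the ethylamino group differ so sharply.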